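Swapping trifluoromethyl for chloro on the urea aryl ring

The source may hold more compounds than are shown below. What is called first, only, known or untested is meant among the compounds shown, and "the series" means these compounds.

The series shares a quinoline urea core, varied only on the aryl ring attached to the urea. Among the compounds with values here, in an ADME assay on Raji cells (Homo sapiens) for cytotoxicity, with a stated time of 72 h (on this read-out higher numbers stand for an effect only at larger amounts of compound and lower numbers for an effect already at smaller amounts), compound 2 `Cc1cc(NC(=O)Nc2cccc(C(F)(F)F)c2)c2ccccc2n1` gives 10000 nM, the only plain number among the three values shown. Compound 1 `Cc1cc(NC(=O)Nc2cc(Cl)cc(Cl)c2)c2ccccc2n1` reaches only a limit, > 25000 nM. Compound 3 `Cc1cc(NC(=O)Nc2ccc([N+](=O)[O-])c(C(F)(F)F)c2)c2ccccc2n1` likewise reaches only a limit, > 25000 nM. Within the data shown here, the single measured step is an at least 2.5-fold higher number from compound 2 to compound 3 (0.39 log units; beyond the scatter), which is the only change for which a size can be given (the limit of > 25000 nM in this assay, at which 2 of the 3 values shown sit).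

Compound 4 `Cc1cc(NC(=O)Nc2cccc(Cl)c2)c2ccccc2n1` differs from compound 2 in one place: chloro in place of trifluoromethyl on an aromatic carbon. No measured step in this assay concerns this exchange, so nothing shown bears on it directly; the two chloro-bearing rings of compound 1 end at a limit, while compound 2 with trifluoromethyl gives a number. A modest move toward weaker effect, or none beyond the scatter, is therefore expected, giving a 1.5-fold higher number from compound 2 to compound 4 (0.18 log units; within the scatter). For compound 4 the estimate in this assay is 15000 nM, within 5000 nM to 40000 nM.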

Compound 4, half-maximal effective concentration: 18000 nM
The estimate for compound 4 lay 1.2-fold (0.08 log units) below the measured number; the measured number falls inside the stated range.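

In this assay, the exchange of trifluoromethyl for chloro on this aromatic carbon now has a measured size: a 1.8-fold higher number from compound 2 to compound 4 (0.26 log units; within the scatter). The two groups therefore cannot be told apart at this place on this read-out. Taking a chloro away from compound 1 gives an at least 1.3-fold lower number from compound 1 to compound 4 (0.14 log units; that floor lies within the scatter), and this size is only a floor because the value of compound 1 is a limit: the limit of > 25000 nM in this assay, at which 2 of the 4 values shown sit.

On these data alone, what an amine or a carboxylic acid on this aromatic carbon would give remains open. So does the effect of hydrogen in place of trifluoromethyl or chloro at this position, and with only a floor for compound 1, the compounds shown do not settle whether a second chloro changes the number at all.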